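The compounds below may be only part of what the source reports. "The series", "measured", "known", "first", "only" and "open" are said of these compounds alone.

Working notes on the series. The compounds share one core, carried on a six-membered aromatic ring of carbon only that bears the varied halogen. Compound 1 `Fc1ccc(F)c(-c2nc3ncccc3o2)c1` gives 18% in a functional assay on the whole organism for inhibition, with Rattus norvegicus as the target, at a dose of 30 mg/kg; on this read-out lower numbers stand for less inhibition and higher numbers for more inhibition at the one dose given (going by the name of the read-out). Compound 2 `Brc1cccc(-c2nc3ncccc3o2)c1` gives 23% in this assay, and compound 3 `Brc1ccccc1-c1nc2cccnc2o1` gives 31% in this assay. On these three numbers compound 2 reads second highest, yet its gaps to compound 1 and to compound 3 both lie within the scatter, so the three are not separable. Compound 4 `Clc1cccc(-c2nc3ncccc3o2)c1` is not yet measured in this assay; it differs from compound 2 by chloro in place of bromo on an aromatic carbon. For the measured compounds named here, no step between measured compounds matches this change, so the data give no direction for it. The step expected, a number 1 percentage points lower from compound 2 to compound 4 (within the scatter), is none beyond the scatter. Compound 4 is expected to give 22% in this assay, within 10% to 35%.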

Compound 4, a percentage reported as inhibition, in the whole organism at one dose (the size of the read-out at that dose, not a potency): 32%
For compound 4 the middle estimate is 10 percentage points below the measured one; the measured number falls inside the stated range.
By their numbers in this assay, from the lowest: compounds 1, 2, 3 and 4 (each within the scatter of the next, the first and the last beyond it).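

Chloro in place of bromo on an aromatic carbon, meta to a group of 9 heavy atoms, gives the only single-place comparison among these compounds. In this assay the step reads a number 9 percentage points higher from compound 2 to compound 4 (within the scatter) and so does not separate the two halogens at this position at the one dose given. No measurement at hand bears on the reason for this result. Still open, as far as these compounds go, is whether an amine, a carboxylic acid or a longer chain in place of the halogen at this position would give a step beyond the scatter.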